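Chloro for Fluoro: A Change Seen Once Before

This account rests on a few compounds, and the source may have more. Where it says the series, first, only, none or still open, it means among the compounds named here.

Of the compounds shown here, three have so far been measured in an assay for inhibition of Alpha amylase (Homo sapiens), with a stated time of 10 min; a higher number here means a weaker inhibitor, a lower number a stronger inhibitor. Compound 1 `COc1ccc(Br)cc1-c1nc2cc(F)ccc2[nH]1` gives 2600 nM. Compound 2 `COc1cc(-c2nc3cc(F)ccc3[nH]2)ccc1OC(C)=O` gives 1680 nM, and compound 3 `COc1cc(-c2nc3cc(Cl)ccc3[nH]2)ccc1OC(C)=O` gives 1680 nM. Compound 1 carries the highest of the three numbers, but its gap to compound 2 and to compound 3 lies within the scatter, so none of the three stands apart. The difference between the core of compound 1 and the core of compound 2 is not broken down here.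

Compound 3 differs from compound 2 in one place, (chloro in place of fluoro on an aromatic carbon), and that change gave no change at the digits printed from compound 2 to compound 3 (within the scatter). The same change is now applied to compound 1, yielding compound 4 `COc1ccc(Br)cc1-c1nc2cc(Cl)ccc2[nH]1`, the difference being (chloro in place of fluoro on an aromatic carbon). The place is described in the same words for both pairs, so this is the same change, occurring twice among these compounds. For compound 4 a step of no change at the digits printed from compound 1 to compound 4 (within the scatter) is expected, because the step of no change at the digits printed from compound 2 to compound 3 (within the scatter) was flat. In this assay compound 4 is estimated at 2600 nM, with a range from 1300 nM to 5200 nM.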

Compound 4, half-maximal inhibitory concentration: 2620 nM
For compound 4 the middle estimate is 1.0-fold (0.00 log units) below the measured one, within the range that was stated.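

In this assay chloro in place of fluoro on an aromatic carbon of the core of compound 1 gave a 1.0-fold higher number from compound 1 to compound 4 (0.00 log units; within the scatter) and so matched the flat step seen on the other core. Across these two cores, the change carried over with no difference that stands out from the scatter. This shows only that fluoro and chloro at this one place could be exchanged on two cores in this one assay; it does not show that the step would stay flat on a further core, or that a step of real size would carry over in the same way, because both steps compared here are flat: the same change on two cores in this assay, no change at the digits printed (within the scatter) from compound 2 to compound 3 and a 1.0-fold higher number (0.00 log units; within the scatter) from compound 1 to compound 4, 1.0-fold (0.00 log units) apart, within the scatter of two such steps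

The compounds shown leave open whether another group at this place, such as a nitrile or an amine, would move the number beyond the scatter. They also leave open what a carboxylic acid in place of the bromo on the core of compound 1 would do.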